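The source may report more compounds than this note shows. Statements on the series, on what has been measured and on what is new or still open speak of the compounds shown alone.

Within the data shown here, in a functional assay on Gurav cells (Homo sapiens) for inhibition, read by sulforhodamine B assay (a lower number here means a stronger inhibitor of growth, a higher number a weaker inhibitor of growth), compound 2 `CN(C)c1ccc(-c2ccc(-c3ccc(-c4nc5c(O)cccc5[nH]4)cc3)cc2)cc1` gives 8210 nM, the higher of the two numbers so far, and compound 1 `Oc1cccc2[nH]c(-c3ccc(-c4ccc(-c5ccccc5)cc4)cc3)nc12` gives 1110 nM. Compound 3 `Oc1cccc2[nH]c(-c3ccc(-c4ccc(-c5cccc(Cl)c5)cc4)cc3)nc12` has 3-chlorophenyl in place of 4-(dimethylamino)phenyl on an aromatic carbon. Among the measured compounds shown here, the only measured guide is a 7.4-fold higher number from compound 1 to compound 2 (0.87 log units; beyond the scatter), with dimethylamino in place of hydrogen on an aromatic carbon. For the measured compounds named here, compound 3 loses that dimethylamino, so a step of similar size back toward a lower number is expected, though the chlorine has no measured precedent. The expected change is a 5.5-fold lower number from compound 2 to compound 3 (0.74 log units; beyond the scatter). The estimate for compound 3 is 1500 nM, with an expected range of 500 nM to 4500 nM.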

Compound 3, concentration for 50% growth inhibition: 2310 nM
For compound 3 the middle estimate is 1.5-fold (0.19 log units) below the measured one, and the stated range covers the measured number.
By their numbers in this assay, from the lowest: compound 1; then compound 3; then compound 2.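

In this assay the change to 3-chlorophenyl gives a 3.6-fold lower number from compound 2 to compound 3 (0.55 log units; beyond the scatter) and so undoes part of the rise seen with dimethylamino. Yet chloro in place of hydrogen still brings a 2.1-fold higher number from compound 1 to compound 3 (0.32 log units; beyond the scatter) and leaves compound 1 the lowest of the three, so dimethylamino is not the only added group here that goes with a higher number. No supporting measurement accounts for either step. The compounds shown leave open whether a methoxy group or a carboxylic acid in this place would also raise the number, and whether chloro behaves the same elsewhere on that ring.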